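This account rests on a few compounds, and the source may have more. Where it says the series, first, only, none or still open, it means among the compounds named here.

Of the compounds shown here, three have so far been measured in an assay on isolated protein for binding affinity to Alpha-2B adrenergic receptor (Homo sapiens); on this read-out higher numbers stand for weaker inhibition and lower numbers for stronger inhibition. Compound 1 `c1ccc(OCC2=NCCN2)c(CC2CC2)c1` gives 501 nM in this assay. Compound 2 `c1ccc(OC2CC2)c(OCC2=NCCN2)c1` gives 794 nM, and compound 3 `CCCc1ccccc1OC(C)C1=NCCN1` gives 537 nM. The number for compound 2 lies within the scatter of both compound 1 and compound 3, so none of the three stands apart from the others on this read-out. Among the measured compounds shown here, the only measured step that touches the same part of the shared core is a 1.6-fold higher number from compound 1 to compound 2 (0.20 log units; within the scatter), in which cyclopropyloxy took the place of cyclopropylmethyl, and it moved the number no further than repeat measurements would. Compound 4 `Brc1ccccc1OCC1=NCCN1` has not yet been measured; it differs from compound 2 by bromo in place of cyclopropyloxy on an aromatic carbon. For the measured compounds named here, no measured step brings in bromo anywhere, so the single change made at that place, which stayed within the scatter, is the only guide. Compound 4 is therefore expected to show a step of a 1.3-fold lower number from compound 2 to compound 4 (0.12 log units; within the scatter), not beyond the scatter. Compound 4 is estimated at 600 nM in this assay, with a range from 200 nM to 2000 nM.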

Compound 4, inhibition constant: 617 nM
The estimate for compound 4 lay 1.0-fold (0.01 log units) below the measured number; the measured number falls inside the stated range.
By their numbers in this assay, from the lowest: compounds 1, 3, 4 and 2 (each within the scatter of the next).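

Bromo, with a single heavy atom, no ring and no hydrogen-bond acceptor, replaced cyclopropyloxy on this aromatic carbon, ortho to a group of 7 heavy atoms, and this assay showed a 1.3-fold lower number from compound 2 to compound 4 (0.11 log units; within the scatter) as the whole effect of that exchange. Set against the cyclopropylmethyl group, the same bromo gave a 1.2-fold higher number from compound 1 to compound 4 (0.09 log units; within the scatter) and so again left the number inside the scatter, which means that three quite different groups at this place now read alike on this assay. No data given here bear on why the number stayed so flat.

The compounds shown leave open whether an amine, a carboxylic acid or a longer chain on this aromatic carbon would carry the number beyond the scatter. Among the compounds shown here, with no step at this place yet outside the scatter, they also leave open whether this position can influence the read-out at all.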